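The compounds below may be only part of what the source reports. "The series", "measured", "known", "first", "only" and "open" are said of these compounds alone.

Within the data shown here, compound 1 `COc1cc(F)ccc1-c1ccnc(Nc2ccc3c(N4CCN(C)CC4)c(C(C)=O)c(=O)oc3c2)n1` is the only compound with a number in a functional assay on MV4-11 cells (Homo sapiens) for inhibition, read by luminescence and CellTiter-Glo, with a stated time of 72 h; on this read-out higher numbers stand for weaker inhibition and lower numbers for stronger inhibition; there compound 1 gives 520 nM. Compound 2 `COc1ccccc1-c1cc(Nc2ccc3c(C)c(C(C)=O)c(=O)oc3c2)ncn1` gives only a limit of the assay, > 10000 nM, in this assay. So compound 1 holds the sole measured value, while the other entry sits at the limit of > 10000 nM in this assay, at which 1 of the 2 values shown sits. Compound 3 `CCN1CCN(c2c(C(C)=O)c(=O)oc3cc(Nc4nccc(-c5ccc(F)cc5OC)n4)ccc23)CC1` differs from compound 1 by methyl in place of hydrogen on a saturated chain carbon bound to an amine nitrogen in a ring. Among the measured compounds shown here, no measured pair shows this change, and the step expected for it in this assay is none beyond the usual scatter, namely a 1.0-fold lower number from compound 1 to compound 3 (0.02 log units; within the scatter). Compound 3 is thus expected to give about 500 nM, between 250 nM and 1000 nM.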

Compound 3, half-maximal inhibitory concentration: 740 nM
Beside the measured number, compound 3's estimate is 1.5-fold (0.17 log units) below it, and the stated range covers the measured number.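

Among these compounds, the swap from 4-methylpiperazin-1-yl to 4-ethylpiperazin-1-yl is the first measured pair at this place, and in this assay it reads a 1.4-fold higher number from compound 1 to compound 3 (0.15 log units; within the scatter). One added methyl here therefore leaves the number inside the usual scatter, and the two compounds cannot be told apart. Nothing measured here bears on a cause for this result. As far as these compounds go, whether a longer chain such as propyl, or a chain ending in a hydroxyl group or a carboxylic acid, would also stay within the scatter in place of the ethyl remains open.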